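A Chlorophenyl Swap at the Assay Limit

This account rests on a few compounds, and the source may have more. Where it says the series, first, only, none or still open, it means among the compounds named here.

In a functional assay on OVCAR-3 cells (Homo sapiens) for antiproliferative activity, read by MTT assay, with a stated time of 24 h (a higher number here means a weaker inhibitor, a lower number a stronger inhibitor), compound 1 `O=C(NNc1ccccc1F)c1ccc(NS(=O)(=O)c2cnc(O)nc2O)cc1` gives > 20000 nM as a limit, not a number. Compound 2 `Cc1ccc(C(=O)NNC(=O)c2ccc(NS(=O)(=O)c3cnc(O)nc3O)cc2)cc1` gives > 20000 nM which is also a limit. Compound 3 `O=C(NNC(=O)c1cccc(Cl)c1)c1ccc(NS(=O)(=O)c2cnc(O)nc2O)cc1` differs from compound 2 by the change 3-chlorophenyl in place of 4-methylphenyl on a carbonyl carbon that puts 3-chlorophenyl in place of 4-methylphenyl on a carbonyl carbon. For the measured compounds named here, the only measured step bearing on this is a step that the two limits leave unreadable from compound 1 to compound 2 and its size cannot be read, since the limit of > 20000 nM in this assay, at which 2 of the 2 values shown sit, covers both ends. No step beyond the scatter is therefore expected in either direction. The expected step is a step that the limit leaves unreadable from compound 2 to compound 3 with neither direction favoured. Compound 3 is estimated at 25000 nM with an expected range from 12000 nM to 60000 nM at its upper end.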

Compound 3, half-maximal inhibitory concentration: 7710 nM
Estimate against measurement, compound 3: 3.2-fold (0.51 log units) above; the measured number lies below the stated range.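

In this assay, putting 3-chlorophenyl in place of 4-methylphenyl on a carbonyl carbon gives an at least 2.5-fold lower number from compound 2 to compound 3 (0.41 log units; beyond the scatter). The change from compound 1 points the same way, with an at least 2.5-fold lower number from compound 1 to compound 3 (0.41 log units; beyond the scatter). This shows for the first time that the group at this place can move the result, though both steps are only minimum sizes, set by a limit: the limit of > 20000 nM in this assay, at which 2 of the 3 values shown sit.

The compounds shown leave open whether the chlorine itself or its place on the ring matters. A 4-chlorophenyl group, or a phenyl ring carrying an amine or a carboxylic acid, would help to separate these.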